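Replacing an amine with an amide on a macrocyclic scaffold

The source may hold more compounds than are shown below. What is called first, only, known or untested is meant among the compounds shown, and "the series" means these compounds.

Of the compounds shown here, three have been measured in a functional assay on SMMC-7721 cells (Homo sapiens) for antiproliferative activity, read by MTT assay, with a stated time of 48 h; a lower number here means a stronger inhibitor, a higher number a weaker inhibitor. Compound 2, `CCN(CC)C/C1=C/C[C@](C)(CCC=C(C)C)/C=C/[C@@H](OC(=O)C=C(C)C)[C@](C)(O)/C=C/C1=O`, gives 570 nM, the lowest of the three numbers. Compound 3, `CC(C)=CCC[C@](C)(/C=C/[C@@H](OC(=O)C=C(C)C)[C@](C)(O)/C=C/C(=O)/C=C/N1CCN(C)CC1)CC=O`, gives 3090 nM, and compound 1, `COC/C1=C/C[C@](C)(CCC=C(C)C)/C=C/[C@@H](OC(=O)C=C(C)C)[C@](C)(OC)/C=C/C1=O`, gives 9380 nM; both of these gaps from compound 2 lie beyond the usual scatter of repeated measurements, so compound 2 is the strongest inhibitor among the three. Compounds 1 and 3 each differ from compound 2 in more than one place, so no single change can be tied to those gaps.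

Compound 4, `CC(C)=CCC[C@]1(C)/C=C/[C@@H](OC(=O)C=C(C)C)[C@](C)(O)/C=C/C(=O)/C(C(=O)N(C(C)C)C(C)C)=C\C1`, is not yet measured. It differs from compound 2 as follows: diisopropylcarbamoyl in place of (diethylamino)methyl on a double-bonded ring carbon. Going by the values given here, with no measured pair that isolates this kind of change, the expectation rests on compound 2 alone. Among the compounds with values here, the number for compound 4 is expected to be higher than the one for compound 2, by a step of a 3.5-fold higher number from compound 2 to compound 4 (0.55 log units; beyond the scatter), somewhat beyond the scatter. Compound 4 is therefore estimated at 2000 nM in this assay, within a range of 500 nM to 8000 nM.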

Compound 4, half-maximal inhibitory concentration: 17200 nM
Beside the measured number, compound 4's estimate is 8.6-fold (0.93 log units) below it; the measured number lies above the stated range.
By their numbers in this assay, from the lowest: compound 2; then compound 3; then compounds 1 and 4 (each within the scatter of the next).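

In this assay, going by these compounds alone, putting diisopropylcarbamoyl in place of (diethylamino)methyl on this double-bonded ring carbon gives a large step, a 30-fold higher number from compound 2 to compound 4 (1.48 log units; beyond the scatter), and this is the first change in the set that can be read on its own. It shows that antiproliferative potency in these cells depends strongly on what this ring carbon carries, since this one replacement, with the rest of the molecule unchanged, weakens the compound well beyond the scatter. No measurement shown here explains why the number rises.

The replacement alters two things at once, a carbonyl taking the place of the methylene link and isopropyl groups taking the place of the ethyl groups on the nitrogen, and the compounds shown do not separate them. A diethylcarbamoyl or a (diisopropylamino)methyl group on the same ring carbon would divide the step into these two parts.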